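A few compounds are considered here, and "the series" means these few. Any claim that something is new, unique, unknown or untested is made for them only; others in the source may bear on it.

Of the compounds shown here, two have been measured in an assay on CHO-K1 cells for displacement of a labelled ligand from Neuronal acetylcholine receptor; alpha4/beta2 (Homo sapiens), read by scintillation counting; a lower number here means a stronger inhibitor, a higher number a weaker inhibitor. Compound 1 `Clc1ccc(OC[C@]23C[C@H]2CCN3)cn1` gives 341 nM in this assay, while compound 2 `CN1[C@H](COc2cccnc2F)C[C@H]2C[C@H]21` gives 31.9 nM in this assay, the lower of the two numbers and well beyond the scatter apart from compound 1. The next compound, compound 3 `Cc1ncccc1OC[C@@H]1C[C@H]2C[C@H]2N1C`, keeps the core of compound 2 but carries methyl in place of fluoro on an aromatic carbon. Within the data shown here, no measured pair shows this change alone, so only an expectation can be given: a modest weakening, with the step from compound 2 to compound 3 expected to be a 2.5-fold higher number from compound 2 to compound 3 (0.40 log units; beyond the scatter) in this assay. Compound 3 is therefore estimated to give about 80 nM in this assay, most likely between 25 nM and 300 nM.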

Compound 3, inhibition constant: 231 nM
Compound 3: the middle estimate sits 2.9-fold (0.46 log units) below what was measured, and the stated range covers the measured number.
By their numbers in this assay, from the lowest: compound 2; then compounds 3 and 1 (each within the scatter of the next).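

Replacing fluoro with methyl on an aromatic carbon next to the ring nitrogen gives a 7.2-fold higher number from compound 2 to compound 3 (0.86 log units; beyond the scatter) in this assay on the shared core. This position therefore distinguishes between two groups of one heavy atom each, neither with a hydrogen-bond donor or acceptor, by more than the scatter. Nothing shown here accounts for the size of this step. Still open, as far as these compounds go, is how a methoxy group or an amine at this position would compare with fluoro and methyl. Also open, from the compounds shown here alone, is whether this step would carry over to another core.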